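Dimethylamino for acetyl on the shared core of compound 1

The source may report more compounds than this note shows. Statements on the series, on what has been measured and on what is new or still open speak of the compounds shown alone.

Compound 1 `COc1cc(C)cc(-c2c(-c3ccnc(-c4ccc(C(C)=O)cc4)c3)cnn2CC#N)c1` stands at the higher of two numbers in a functional assay on HT-29 cells (Homo sapiens) for inhibition, read by sulforhodamine B assay, with a stated time of 48 h (a higher number here means a weaker inhibitor of growth, a lower number a stronger inhibitor of growth), giving 3210 nM. Compound 2 `COc1cc(C)cc(-c2nn(CC#N)cc2-c2ccnc(-c3ccc(N(C)C)cc3)c2)c1`, which carries a dimethylamino group on a differently joined core, gives in this assay 481 nM, a gap well beyond the scatter. Compound 3 `COc1cc(C)cc(-c2c(-c3ccnc(-c4ccc(N(C)C)cc4)c3)cnn2CC#N)c1` arises from compound 1 by the change (dimethylamino in place of acetyl on an aromatic carbon). Among the compounds with values here, no directly comparable step is measured, so the expected step of a 4.6-fold lower number from compound 1 to compound 3 (0.66 log units; beyond the scatter) rests on compound 2 alone and is expected to be a clear drop. Compound 3 is expected to give 700 nM, within 250 nM to 2000 nM, because compound 2 gives 481 nM.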

Compound 3, concentration for 50% growth inhibition: 37.7 nM
Compound 3: the middle estimate sits 19-fold (1.27 log units) above what was measured; measured number below the stated range.
By their numbers in this assay, from the lowest: compound 3; then compound 2; then compound 1.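

In this assay, within the data shown here, the exchange of 4-acetylphenyl for 4-(dimethylamino)phenyl gives an 85-fold lower number from compound 1 to compound 3 (1.93 log units; beyond the scatter) and is the first reading of a single change on the shared core. It shows that the group on this aromatic carbon, para to a large group, weighs heavily on growth inhibition in these compounds. Nothing at hand accounts for the size of this step. On these data alone, whether a cyclic amine such as pyrrolidine or morpholine, or a methoxy group, would serve here stays open. So does the effect of an acetyl group on the differently joined core of compound 2.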